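Swapping the Benzoxazole for a Benzothiazole

A few compounds are considered here, and "the series" means these few. Any claim that something is new, unique, unknown or untested is made for them only; others in the source may bear on it.

Among the compounds with values here, in a functional assay on MCF7 cells (Homo sapiens) for cytotoxicity, read by MTT assay, with a stated time of 24 h, tested at 32 ug/mL (on this read-out higher numbers stand for a stronger effect at the one concentration tested and lower numbers for a weaker effect), compound 2 `Cc1ccc2oc(SCC(=O)Nc3ccc(-c4nc(-c5ccccc5)c(-c5ccccc5)n4C)cc3)nc2c1` gives 57.7%, and compound 1 `Cn1c(-c2ccc(NC(=O)CSc3nc4cc(Cl)ccc4o3)cc2)nc(-c2ccccc2)c1-c1ccccc1` gives 59.7%; the two numbers lie within the scatter of each other, as the only measured step, a number 2 percentage points lower from compound 1 to compound 2 (within the scatter), shows. Compound 3 `Cn1c(-c2ccc(NC(=O)CSc3nc4ccccc4s3)cc2)nc(-c2ccccc2)c1-c1ccccc1` differs from compound 2 by 1,3-benzothiazol-2-yl in place of 5-methyl-1,3-benzoxazol-2-yl on a sulfur. Within the data shown here, no measured step touches this part of the molecule, so the one known step offers no direct guide here. The expected step of a number 0.3 percentage points higher from compound 2 to compound 3 (within the scatter) is therefore none beyond the scatter. For compound 3 the estimated value in this assay is 58%, with a range from 44% to 72%.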

Compound 3, a percentage reported as activity, at one concentration (the size of the read-out at that concentration, not a potency): 59%
Beside the measured number, compound 3's estimate is 1 percentage points below it, within the range that was stated.
By their numbers in this assay, from the lowest: compounds 2, 3 and 1 (each within the scatter of the next).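

In this assay the step to 1,3-benzothiazol-2-yl on the sulfur gives a number 1.3 percentage points higher from compound 2 to compound 3 (within the scatter) and a number 0.7 percentage points lower from compound 1 to compound 3 (within the scatter). So at this position, the ring sulfur of the new group and the absence of a methyl or chloro substituent leave the read-out within the scatter for these three compounds. Nothing measured here explains this similarity.

On these data alone, the read-out gives the size of the effect at one concentration only, and how these compounds compare at other concentrations remains open. As far as these compounds go, it also remains open whether an amine or a carboxylic acid on the benzothiazole ring would keep the read-out in this range.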